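This account rests on a few compounds, and the source may have more. Where it says the series, first, only, none or still open, it means among the compounds named here.

Among the compounds with values here, in a functional assay on KARPAS-299 cells (Homo sapiens) for inhibition, read by CellTiter-Glo, with a stated time of 96 h (a higher number here means a weaker inhibitor, a lower number a stronger inhibitor), compound 2 `Cc1cc(Nc2ncc(Cl)c(Nc3cn(C)nc3S(=O)(=O)C(C)C)n2)c(OC(C)C)cc1C1CNC1` gives 60 nM, the highest of the three numbers so far, set against compound 3 `CCNC(=O)c1cc(OC2CC2)c(Nc2ncc(Cl)c(Nc3cn(C)nc3S(=O)(=O)C(C)C)n2)cc1C` at 20 nM and compound 1 `Cc1cc(Nc2ncc(Cl)c(Nc3cn(C)nc3S(=O)(=O)C(C)C)n2)c(OC(C)C)cc1C1CCN(C)C1` at 11 nM. The next change leads to compound 4 `Cc1cc(Nc2ncc(Cl)c(Nc3cn(C)nc3S(=O)(=O)C(C)C)n2)c(OC(C)C)cc1C1CCNC1`, with pyrrolidin-3-yl in place of azetidin-3-yl on an aromatic carbon. Within the data shown here, one measured step bears on it: a 5.5-fold higher number from compound 1 to compound 2 (0.74 log units; beyond the scatter). Among the measured compounds shown here, that step also involves the methyl group of 1-methylpyrrolidin-3-yl, which compound 4 lacks, and no measurement yet separates that methyl group from ring size. Only part of that step is therefore expected to reverse in this assay, towards a lower number. The expected change is a 2.4-fold lower number from compound 2 to compound 4 (0.38 log units; beyond the scatter). The estimated value for compound 4 is 25 nM, with an expected range of 10 nM to 60 nM.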

Compound 4, half-maximal inhibitory concentration: 28 nM
Estimate against measurement, compound 4: 1.1-fold (0.05 log units) below; low and high end bracket the measured number.
By their numbers in this assay, from the lowest: compounds 1, 3 and 4 (each within the scatter of the next, the first and the last beyond it); then compound 2.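

In this assay ring size and the methyl group on the ring nitrogen can now be read apart: enlarging the unsubstituted ring (a 2.1-fold lower number from compound 2 to compound 4 (0.33 log units; beyond the scatter)) and removing that methyl group (a 2.5-fold higher number from compound 1 to compound 4 (0.41 log units; beyond the scatter)) are each modest steps beyond the scatter. Both changes therefore contribute to the gap between compound 1 and compound 2. No supporting data explain either step. Still open, as far as these compounds go, is how a piperidinyl group would read at this place on the aromatic ring, and whether an ethyl group on the ring nitrogen would behave like methyl.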